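Liver microsome stability of a dichlorofluorophenyl analogue

The source may report more compounds than this note shows. Statements on the series, on what has been measured and on what is new or still open speak of the compounds shown alone.

Three compounds from one series were measured in an ADME assay on microsomes from liver (Canis lupus familiaris) for metabolic stability; on this read-out higher numbers stand for a longer-lived compound and lower numbers for a shorter-lived compound. Compound 1 `Nc1nc(NCCNc2ncc(-c3ncc[nH]3)c(-c3cc(F)ccc3F)n2)ccc1[N+](=O)[O-]` carries a 2,5-difluorophenyl group; in this assay compound 1 gives > 0.5 h, which is a limit of the assay and not a number. Compound 2 `Nc1nc(NCCNc2ncc(-c3ncc[nH]3)c(-c3cc(F)ccc3Cl)n2)ccc1[N+](=O)[O-]` differs from it by chloro in place of fluoro on an aromatic carbon. In this assay compound 2 gives > 0.5 h, again only a limit. Compound 3 `Nc1nc(NCCNc2ncc(-c3ncc[nH]3)c(-c3cc(F)c(Cl)cc3F)n2)ccc1[N+](=O)[O-]` differs from compound 1 by chloro in place of hydrogen on an aromatic carbon. In this assay compound 3 gives > 0.5 h, also a limit. The measured steps a step that the two limits leave unreadable from compound 1 to compound 2, a step that the two limits leave unreadable from compound 1 to compound 3 and a step that the two limits leave unreadable from compound 2 to compound 3 therefore cannot be sized, because of the limit of > 0.5 h in this assay, at which 3 of the 3 values shown sit.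

Compound 4 `Nc1nc(NCCNc2ncc(-c3ncc[nH]3)c(-c3cc(F)c(Cl)cc3Cl)n2)ccc1[N+](=O)[O-]` is not yet measured. It differs from compound 3 by chloro in place of fluoro on an aromatic carbon. This is the same kind of change as chloro in place of fluoro on an aromatic carbon, though here the place is also meta to a chloro group. Since the earlier step that the two limits leave unreadable from compound 1 to compound 2 is unreadable, the expected step that the limit leaves unreadable from compound 3 to compound 4 in this assay rests only on all three measured values sitting at the limit. Compound 4 is accordingly expected to give about 1 h in this assay, most likely reported again as a limit, with a range from 0.4 h to 3 h.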

Compound 4, half-life: > 0.5 h
Compound 4: only a limit was reported (the forecaster's own chance of this, stated with the estimate: 75%); the middle value is on the limit's open side.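

In this assay compound 4 gives > 0.5 h, which is a limit and not a number, so no step from compound 1, compound 2 or compound 3 to compound 4 can be read: the limit of > 0.5 h in this assay, at which 4 of the 4 values shown sit.

The compounds shown leave open what the half-lives of these compounds actually are, and whether chloro in place of fluoro on an aromatic carbon alters them at all.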